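A few compounds are considered here, and "the series" means these few. Any claim that something is new, unique, unknown or untested is made for them only; others in the source may bear on it.

Measured compounds:
compound 1 `CCOC(=O)C1C(=O)C(C(=O)OCC)[C@H](c2ccc([N+](=O)[O-])cc2)N(Cc2ccccc2)[C@@H]1c1ccc([N+](=O)[O-])cc1` — > 100 uM
compound 2 `Clc1cccc(Cl)c1CO/N=C/C1CCN(CCCc2ccccc2)CC1` — 28.4 uM
compound 3 `COC(=O)C1C(=O)C(C(=O)OC)[C@H](c2ccccn2)N(Cc2ccccc2)[C@@H]1c1ccccn1` — 34 uM

All three were tested in an ADME assay on J774.1 cells (Mus musculus) for cytotoxicity, with a stated time of 48 h; on this read-out lower numbers stand for an effect already at smaller amounts and higher numbers for an effect only at larger amounts of compound. Compound 1 gives only a limit in this assay, > 100 uM, and the limit of > 100 uM in this assay, at which 1 of the 3 values shown sits, records it as a limit rather than a number. Of the two numbers recorded, compound 2 has the lower one, 28.4 uM, and compound 3 stands nearest to it at 34 uM; the two lie within the scatter of each other, so no order between them is claimed. For the measured compounds named here, no pair of measured compounds differs in a single place, so no measured step is available as a guide.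

Compound 4, `O/N=C/C1CCN(CCCc2ccccc2)CC1`, has not yet been measured. It differs from compound 2 as follows: hydrogen in place of 2,6-dichlorobenzyl on an oxygen. Going by the values given here, with no measured step to rest on, the step from compound 2 to compound 4 is expected to be a 2.1-fold higher number from compound 2 to compound 4 (0.32 log units; beyond the scatter), toward a higher number, somewhat beyond the scatter. Compound 4 is accordingly estimated at 60 uM, with a range from 25 uM to 150 uM.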

Compound 4, concentration for half-maximal effect: > 100 uM
Compound 4 was reported as a limit (the forecaster's own chance of this, stated with the estimate: 30%); at least 1.6-fold (0.22 log units) between middle value and limit.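

In this assay, hydrogen in place of 2,6-dichlorobenzyl on an oxygen whose other neighbour is a double-bonded nitrogen gives an at least 3.5-fold higher number from compound 2 to compound 4 (0.54 log units; beyond the scatter). For the compounds shown here, this is the first single change that can be read in the set, and it shows that the cytotoxicity number at this position responds to the change, with the lower number going with the 2,6-dichlorobenzyl group. Only the minimum size of the step is known, as compound 4 is recorded as a limit: the limit of > 100 uM in this assay, at which 2 of the 4 values shown sit.

The compounds shown leave open whether the two chlorine atoms or the benzyl group as a whole carry this difference, and an unsubstituted benzyl on this oxygen would separate the two. They also leave open whether a small group such as methyl on this oxygen would stand nearer compound 2 or compound 4.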